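The compounds below may be only part of what the source reports. "The series", "measured", "known", "first", "only" and "open" are said of these compounds alone.

Working notes on the series, read in a functional assay with Felis catus as the target; on this read-out higher numbers stand for an effect only at larger amounts of compound and lower numbers for an effect already at smaller amounts. Compound 1 (`Cc1nc(O)c(C#N)c(NCc2ccccn2)n1`) gives 180000 nM, and compound 2 (`CCc1nc(O)c(C#N)c(NCc2cccnc2)n1`) gives 86000 nM. Compound 2 therefore holds the lower of the two numbers, and the gap up to compound 1 lies beyond the scatter. Going by the values given here, with only two measurements, this places compound 2 within a very small set and shows no trend.

The next entry is compound 3 (`CC(C)(C)c1nc(O)c(C#N)c(NCc2cccnc2)n1`), which differs from compound 2 in one group: tert-butyl in place of ethyl on an aromatic carbon. The tert-butyl stands in place of ethyl on an aromatic carbon, between two ring nitrogen atoms. Among the compounds with values here, no measured pair differs in one place only, so the data give no direct size for a change of this kind. The expectation therefore stays anchored on compound 2 at 86000 nM. No shift beyond the scatter is expected in this assay, with the estimated change being a 1.2-fold lower number from compound 2 to compound 3 (0.09 log units; within the scatter). For compound 3 the expected value is 70000 nM, with an estimated range of 20000 nM to 200000 nM.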

Compound 3, half-maximal effective concentration: 110000 nM
Beside the measured number, compound 3's estimate is 1.6-fold (0.20 log units) below it, and the stated range covers the measured number.
By their numbers in this assay, from the lowest: compounds 2, 3 and 1 (each within the scatter of the next, the first and the last beyond it).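

In this assay, the step of a 1.3-fold higher number from compound 2 to compound 3 (0.11 log units; within the scatter) gives the series its first comparison that differs in one place only, at the aromatic carbon between two ring nitrogen atoms. At this position, tert-butyl with its 4 heavy atoms and ethyl with its 2 heavy atoms cannot be told apart on this read-out, so the added carbon count leaves no effect beyond the scatter in this single pair. No measured property in the material at hand bears on this result.

On these data alone, it remains open whether this tolerance holds for groups of another kind at the same carbon, such as an amine, a carboxylic acid, a phenyl ring or a longer chain, since one pair of alkyl groups says nothing about them. Compound 1 differs from both compound 2 and compound 3 in more than one place, so the series still gives no separate reading of the alkyl group and the remainder of the substituent on the shared core.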